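Aryl swap on a six-ring fused core: notes toward compound 3

A few compounds are considered here, and "the series" means these few. Any claim that something is new, unique, unknown or untested is made for them only; others in the source may bear on it.

Measured so far:
- compound 1 `COc1ccc(-c2c3ccc4ccccc4c3nc3c2c(C)nc2c4ccccc4ccc32)cc1` — in a functional assay, with a stated time of 90 s (a lower number here means a stronger inhibitor, a higher number a weaker inhibitor), compound 1 gives 176 ug/mL
- compound 2 `Cc1nc2c3ccccc3ccc2c2nc3c(ccc4ccccc43)c(-c3ccccc3S)c12` — in this assay compound 2 gives 158 ug/mL

Compound 2 holds the lowest of the two numbers recorded in this assay, with compound 1 nearest; the step of a 1.1-fold lower number from compound 1 to compound 2 (0.05 log units; within the scatter) is within the scatter, so the two are not separated on these data.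

The step under consideration leads from compound 2 to compound 3 `Cc1nc2c3ccccc3ccc2c2nc3c(ccc4ccccc43)c(-c3ccc(O)cc3)c12`. The change is 4-hydroxyphenyl in place of 2-sulfanylphenyl on an aromatic carbon. The leaving and entering groups match in heavy-atom count, ring type, donor count and acceptor count, differing in the heteroatom and in where it sits on the ring.

Going by the values given here, only one measured step exists, a 1.1-fold lower number from compound 1 to compound 2 (0.05 log units; within the scatter), and it concerns a different pair of aryl groups. It shows that exchanging one substituted phenyl for another at this position left the number within the scatter. Among the compounds with values here, no measured step involves the 4-hydroxyphenyl group itself. On that basis the expectation for compound 3 in this assay is a step of a 1.0-fold higher number from compound 2 to compound 3 (0.02 log units; within the scatter), that is, none beyond the scatter. Compound 3 is therefore estimated at 165 ug/mL, with a range from 80 ug/mL to 340 ug/mL.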

Compound 3, half-maximal inhibitory concentration: 99 ug/mL
Compound 3: the middle estimate sits 1.7-fold (0.22 log units) above what was measured; low and high end bracket the measured number.
By their numbers in this assay, from the lowest: compounds 3, 2 and 1 (each within the scatter of the next).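

In this assay, 4-hydroxyphenyl in place of 2-sulfanylphenyl on this aromatic carbon, opposite the ring nitrogen, gives a 1.6-fold lower number from compound 2 to compound 3 (0.20 log units; within the scatter), and hydrogen in place of methyl on the oxygen gives a 1.8-fold lower number from compound 1 to compound 3 (0.25 log units; within the scatter). Going by these compounds alone, the position now carries three substituted phenyl groups, and every step among them lies within the scatter, including the first pair that differs only by that methyl on the oxygen, so neither exchanging the sulfur-bearing group for the oxygen-bearing one nor uncapping the hydroxyl separates these compounds on the present numbers. No supporting data bear on these steps, so the small differences have no stated explanation.

The step from 2-sulfanylphenyl to 4-hydroxyphenyl changes both the heteroatom and its place on the ring, so the compounds shown leave those two changes unseparated, and a 2-hydroxyphenyl or 4-sulfanylphenyl group would be needed to tell them apart. Also open, as far as these compounds go, is whether any group at this carbon moves the number beyond the scatter, for instance an amine or a carboxylic acid on the phenyl ring, or a longer chain on the oxygen.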